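Piperazine dithiocarbamate triazoles: removing the tert-butoxycarbonyl

The source may hold more compounds than are shown below. What is called first, only, known or untested is meant among the compounds shown, and "the series" means these compounds.

Measured in a functional assay on ECa-109 cells (Homo sapiens) for inhibition, read by MTT assay, with a stated time of 72 h; a lower number here means a stronger inhibitor, a higher number a weaker inhibitor:
compound 1 `COc1ccc(Cn2cc(CSC(=S)N3CCN(C(=O)OCc4ccccc4)CC3)nn2)cc1` gives 58300 nM
compound 2 `COc1ccc(Cn2cc(CSC(=S)N3CCN(C(=O)OC(C)(C)C)CC3)nn2)cc1` gives 36800 nM

In this assay compound 2 stands at the lowest of the two numbers; the nearest is compound 1, and the step of a 1.6-fold lower number from compound 1 to compound 2 (0.20 log units; within the scatter) is within the scatter, so no order between the two is claimed. Compound 3 `COc1ccc(Cn2cc(CSC(=S)N3CCNCC3)nn2)cc1` differs from compound 2 by hydrogen in place of tert-butoxycarbonyl on an amine nitrogen in a ring. Among the compounds with values here, the only measured step, a 1.6-fold lower number from compound 1 to compound 2 (0.20 log units; within the scatter), swaps benzyl for tert-butyl and keeps the tert-butoxycarbonyl in place, so it bears only weakly on this change. Within the data shown here, no step shows that group leaving. Compound 3 is therefore expected to give a number near that of compound 2. The estimate for compound 3 is 40000 nM, with a range of 10000 nM to 150000 nM. For compound 3 this means an expected step of a 1.1-fold higher number from compound 2 to compound 3 (0.04 log units; within the scatter) in this assay.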

Compound 3, half-maximal inhibitory concentration: > 128000 nM
Compound 3 ended at the assay's limit; the forecaster's own chance of this, stated with the estimate: 15%; middle value at least 3.2-fold (0.50 log units) from the limit.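

In this assay compound 3 stands at a limit of the assay, not at a number: the limit of > 128000 nM in this assay, at which 1 of the 3 values shown sits.

Hydrogen on this amine nitrogen in a ring gives an at least 3.4-fold higher number from compound 2 to compound 3 (0.54 log units; beyond the scatter) against tert-butoxycarbonyl and an at least 2.1-fold higher number from compound 1 to compound 3 (0.34 log units; beyond the scatter) against benzyloxycarbonyl. The two groups could not be separated from each other, but this position does respond when the substituent leaves altogether.

Going by these compounds, the true size of both steps stays open, as only a limit is available for compound 3. Also open, on these data alone, is whether a methyl or an acetyl group on this nitrogen would keep the number of compound 2.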